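The compounds below may be only part of what the source reports. "The series", "measured", "known", "first", "only" and "open" are said of these compounds alone.

Measured so far:
compound 1, `COc1cccc(/C=C2\CCC/C(=C\c3cccc(Cl)c3)C2=O)c1OC`: 9100 nM
compound 2, `COc1cc(/C=C2\CCC/C(=C\c3cccc(OC)c3OC)C2=O)cc(OC)c1`: 3800 nM
compound 3, `COc1ccc(/C=C2\CCC/C(=C\c3ccccc3Cl)C2=O)cc1OC`: 7100 nM

In a functional assay on SW-620 cells (Homo sapiens) for cytotoxicity, read by MTT assay, with a stated time of 72 h (a lower number here means a stronger inhibitor, a higher number a weaker inhibitor), compound 3 holds the second highest of the three numbers; compound 1 lies nearest and compound 2 furthest, yet both gaps fall within the usual scatter, so no one of the three can be called stronger or weaker than another. Compound 4, `COc1ccc(/C=C2\CCC/C(=C\c3cccc(O)c3)C2=O)cc1OC`, awaits measurement. It differs from compound 3 in one place: 3-hydroxyphenyl in place of 2-chlorophenyl on a double-bonded chain carbon bound to a double-bonded ring carbon. Among the measured compounds shown here, no measured pair shows this change, so there is nothing yet to tell how large a step it brings. Given that the three known values sit within scatter of one another, the step in this assay is expected to be none beyond the scatter, a 1.2-fold lower number from compound 3 to compound 4 (0.07 log units; within the scatter). Compound 4 is therefore estimated at 6000 nM, with a range from 2000 nM to 20000 nM.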

Compound 4, half-maximal inhibitory concentration: 1900 nM
Compound 4: the middle estimate sits 3.2-fold (0.50 log units) above what was measured, and the stated range ends above it.
By their numbers in this assay, from the lowest: compounds 4, 2, 3 and 1 (each within the scatter of the next, the first and the last beyond it).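

Among the compounds shown here, replacing 2-chlorophenyl with 3-hydroxyphenyl in this assay gives a 3.7-fold lower number from compound 3 to compound 4 (0.57 log units; beyond the scatter) and is the only step here that clears the scatter, so the group at this double-bonded chain carbon can shift the number. Both the ring substituent and its numbered position change in this single swap, so this pair cannot show which of the two matters. As far as these compounds go, it remains open whether 2-hydroxyphenyl would give a similar number, and whether 3-aminophenyl or 3-carboxyphenyl could take the place of 3-hydroxyphenyl. No supporting evidence is available to explain the step.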